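The compounds below may be only part of what the source reports. "The series", "measured", "known", "first", "only" and "open" are said of these compounds alone.

Working notes on the series. Compound 1, `O=C(/C=C/c1ccc(F)cc1)NS(=O)(=O)c1ccccc1`, gives 2.1 ug/mL in a functional assay on B16-F10 cells (Mus musculus) for antiproliferative activity, read by ELISA and MTT assay, with a stated time of 48 h; on this read-out higher numbers stand for weaker inhibition and lower numbers for stronger inhibition. Among the compounds with values here, compound 2, `O=C(/C=C/c1ccc(Br)cc1)NS(=O)(=O)c1ccccc1`, gives 3.9 ug/mL in this assay; it holds the higher of the two numbers measured so far, its nearest neighbour being compound 1, but the step of a 1.9-fold higher number from compound 1 to compound 2 (0.27 log units; within the scatter) stays within the scatter, so no order between the two can be read from these data. The next compound, compound 3, `CN(C)c1ccc(/C=C/C(=O)NS(=O)(=O)c2ccccc2)cc1`, is not yet measured. (dimethylamino in place of bromo on an aromatic carbon). Within the data shown here, the only measured step, a 1.9-fold higher number from compound 1 to compound 2 (0.27 log units; within the scatter), also replaces one group on an aromatic carbon with another and stayed within the scatter; it is the sole point of comparison, and no measured step brings in a dimethylamino group. The expectation for compound 3 is therefore a step of a 1.3-fold lower number from compound 2 to compound 3 (0.11 log units; within the scatter) that does not exceed the scatter, with wide uncertainty. Compound 3 is estimated at 3 ug/mL, with a range from 1.2 ug/mL to 8 ug/mL.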

Compound 3, half-maximal inhibitory concentration: 2.3 ug/mL
For compound 3 the middle estimate is 1.3-fold (0.12 log units) above the measured one; the measured number falls inside the stated range.
By their numbers in this assay, from the lowest: compounds 1, 3 and 2 (each within the scatter of the next).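

In this assay, dimethylamino on this aromatic carbon, para to a large group, replaces bromo with a group of 3 heavy atoms and 1 hydrogen-bond acceptor, and the result is a 1.7-fold lower number from compound 2 to compound 3 (0.23 log units; within the scatter). Set against fluoro at the same place, the result is a 1.1-fold higher number from compound 1 to compound 3 (0.04 log units; within the scatter), so the first group here that is not a halogen also stays within the scatter, and fluoro, bromo and dimethylamino cannot be told apart on this read-out. Nothing measured on these compounds bears on why the three numbers lie so close.

Going by these compounds, it remains open whether this position stays as undiscriminating with a carboxylic acid, a primary amine or a longer alkoxy chain in place of these groups. On these data alone, the effect of changes elsewhere on the shared core also remains open.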